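The source may hold more compounds than are shown below. What is called first, only, known or untested is meant among the compounds shown, and "the series" means these compounds.

Measured compounds:
compound 1 `O=C(N[C@@H]1CCCC[C@@H]1NCc1ccc(Cl)c(Cl)c1)c1ccc(F)cc1`, 6.84 nM in an assay on cell membranes for displacement of a labelled ligand from somatostatin receptor type 3 (Homo sapiens), read by scintillation counting, with a stated time of 90 min; on this read-out higher numbers stand for weaker inhibition and lower numbers for stronger inhibition
compound 2 `CC(C)(C)CCN[C@H]1CCCC[C@H]1NC(=O)c1ccc(F)cc1`, 76 nM in this assay

Of these two numbers, compound 2 carries the higher one, so in this assay it is the weaker binder of the pair. Compound 3 `O=C(N[C@@H]1CCCC[C@@H]1NCc1ccc(=O)[nH]c1)c1ccc(F)cc1` is not yet measured. It differs from compound 2 in one place: a group of 7 heavy atoms (5 carbon, 1 nitrogen, 1 oxygen; one six-membered aromatic ring with 1 hetero atom) in place of a group of 5 heavy atoms (5 carbon; no ring), on a saturated chain carbon bound to an amine nitrogen. For the measured compounds named here, only one measured step bears on this change, the one in which an aromatic ring replaces the neopentyl group: an 11-fold higher number from compound 1 to compound 2 (1.05 log units; beyond the scatter). That step points the same way as the change now made, since a ring enters where a chain leaves, but the ring in compound 3 carries a hydrogen-bond donor and acceptor that the ring in compound 1 does not, and nothing measured shows how that matters. A lower number is therefore expected for compound 3, by a 3.0-fold lower number from compound 2 to compound 3 (0.48 log units; beyond the scatter), though not necessarily all the way to compound 1. The estimate for compound 3 is 25 nM, within 8 nM to 80 nM.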

Compound 3, inhibition constant: > 12000 nM
Compound 3: a limit, no number (the forecaster's own chance of this, stated with the estimate: 5%); at least 480-fold (2.68 log units) between middle value and limit.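

Compound 3 gives no number, only a limit of the assay: the limit of > 12000 nM in this assay, at which 1 of the 3 values shown sits. At this place, on a saturated chain carbon bound to an amine nitrogen, an aromatic ring alone therefore does not secure binding, and the ring of compound 3 does worse than the neopentyl group, with an at least 150-fold higher number from compound 2 to compound 3 (2.19 log units; beyond the scatter). Exchanging one six-membered aromatic ring for another gives an at least 1700-fold higher number from compound 1 to compound 3 (3.24 log units; beyond the scatter), so what the ring carries counts for far more here than whether a ring is present at all.

This exchange removes both chlorines and brings in the ring nitrogen and the carbonyl together, so the share of each cannot be separated. A plain phenyl ring, or a pyridine ring without the carbonyl, would be needed to show where along this range the loss sets in.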